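The source may hold more compounds than are shown below. What is called first, only, known or untested is meant among the compounds shown, and "the series" means these compounds.

Two compounds of this series have readings in an ADME assay on MT4 cells (Homo sapiens) for cytotoxicity, read by MTT assay; on this read-out higher numbers stand for lower toxicity in this test and lower numbers for higher toxicity in this test: compound 1 (`CCc1c(Cc2c(Cl)cccc2Cl)nc(SCC(=O)c2ccc(OC)cc2)[nH]c1=O`) and compound 2 (`CCc1c(Cc2c(F)cccc2F)nc(SCC(=O)c2ccc(F)cc2)[nH]c1=O`). Compound 1 gives > 54000 nM, which is a limit of the assay and not a number. Compound 2 gives > 60000 nM, which is also a limit, so compound 2 stands without an exact value. Compound 3 (`CCc1c(Cc2c(F)cccc2F)nc(SCC(=O)c2ccc(OC)cc2)[nH]c1=O`) has not yet been measured in this assay. It differs from compound 2 in one place, with methoxy in place of fluoro on an aromatic carbon, para to a large group: methoxy in place of fluoro on an aromatic carbon. Going by the values given here, no step between measured compounds is available as a guide, so no change beyond the scatter is expected in this assay. The estimated step of an at least 1.0-fold lower number from compound 2 to compound 3 (0.01 log units; that floor lies within the scatter) is expected to stay within that scatter. For compound 3 the expected value is 58000 nM, with an estimated range of 25000 nM to 100000 nM.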

Compound 3, half-maximal cytotoxic concentration: > 58000 nM
Compound 3: a limit, no number; the forecaster's own chance of this, stated with the estimate: 75%; the middle value sits exactly at the limit.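

Compound 3, like compound 1 and compound 2, reads only as a limit in this assay, so neither the step from compound 2 to compound 3 nor the step from compound 1 to compound 3 can be read. The compounds shown leave open at what concentration any of the three becomes toxic to these cells.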